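The compounds below may be only part of what the source reports. "The series", "measured", "known", "first", "only" and "open" are said of these compounds alone.

In a functional assay on KB cells (Homo sapiens) for antiproliferative activity, read by sulforhodamine B assay, with a stated time of 3 days (a higher number here means a weaker inhibitor of growth, a lower number a stronger inhibitor of growth), compound 2 `CN(C)CC(=O)Nc1cccc(Nc2ncc(F)c(Nc3ccc(F)cc3)n2)c1` gives 1260 nM, the lowest of the three numbers in hand. Compound 1 `O=C(c1cccc(Nc2ncc(F)c(Nc3ccc(F)cc3)n2)c1)N1CCCCC1` gives 14800 nM and compound 3 `O=C(Nc1ccccn1)c1cccc(Nc2ncc(F)c(Nc3ccc(F)cc3)n2)c1` gives 20000 nM; the steps of a 12-fold lower number from compound 1 to compound 2 (1.07 log units; beyond the scatter) and a 16-fold higher number from compound 2 to compound 3 (1.20 log units; beyond the scatter) both set compound 2 apart, while a 1.4-fold higher number from compound 1 to compound 3 (0.13 log units; within the scatter) leaves compounds 1 and 3 together. Compound 4 `O=C(Nc1cccc(Nc2ncc(F)c(Nc3ccc(F)cc3)n2)c1)c1cccc([N+](=O)[O-])c1` differs from compound 2 by 3-nitrophenyl in place of (dimethylamino)methyl on a carbonyl carbon. Going by the values given here, no measured step replaces the group on this carbonyl carbon while keeping the amide-type nitrogen, so the closest guidance is that the two other compounds, lacking the (dimethylamino)methyl group of compound 2, both stand well above it; the one step on a carbonyl carbon, a 1.4-fold higher number from compound 1 to compound 3 (0.13 log units; within the scatter), is small. Compound 4 is therefore expected to move toward the numbers of compounds 1 and 3, with a 6.3-fold higher number from compound 2 to compound 4 (0.80 log units; beyond the scatter) estimated, in a sentence on its own. For compound 4 the estimate in this assay is 8000 nM, with a range from 2000 nM to 30000 nM.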

Compound 4, concentration for 50% growth inhibition: 15100 nM
Compound 4: middle estimate off by 1.9-fold (0.28 log units), on the low side; low and high end bracket the measured number.
By their numbers in this assay, from the lowest: compound 2; then compounds 1, 4 and 3 (each within the scatter of the next).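

In this assay, a change confined to the group on the carbonyl carbon, with the amide-type nitrogen kept, gives a 12-fold higher number from compound 2 to compound 4 (1.08 log units; beyond the scatter) and so shows that this position alone can carry a gap of the size seen earlier. Compound 4, with its 3-nitrophenyl, sits within the scatter of compounds 1 and 3, leaving compound 2, with its (dimethylamino)methyl, alone at the low end of the four numbers. Nothing available accounts for this step.

The compounds shown leave open whether the lower number of compound 2 depends on the dimethylamino group itself or would also appear with a piperidine, a primary amine or a longer chain between that amine and the carbonyl. They also leave open whether an unsubstituted phenyl or a carboxylic acid on the ring would read like the 3-nitrophenyl.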